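Dropping One Chloro Group From Compound 2

The source may hold more compounds than are shown below. What is called first, only, known or untested is meant among the compounds shown, and "the series" means these compounds.

Within the data shown here, compound 2 `ClCc1ccc(Cn2cnc3nc(Cl)nc(Cl)c32)cc1` gives 3460 nM in a functional assay on SN12C cells (Homo sapiens) for cytotoxicity, read by sulforhodamine B assay, with a stated time of 48 h (on this read-out lower numbers stand for stronger inhibition of growth and higher numbers for weaker inhibition of growth), the lower of the two numbers measured so far. Compound 1 `ClCc1cccc(Cn2cnc3ncnc(Cl)c32)c1` gives 20400 nM in this assay, a gap from compound 2 that lies beyond the scatter. Compound 3 `ClCc1ccc(Cn2cnc3ncnc(Cl)c32)cc1` keeps the core of compound 2 but carries hydrogen in place of chloro on an aromatic carbon. Among the measured compounds shown here, no step between measured compounds that differ in only one place is available to anchor this change, so its size is uncertain. The change is expected to weaken growth inhibition, with a step of a 2.9-fold higher number from compound 2 to compound 3 (0.46 log units; beyond the scatter) that lies beyond the scatter. Compound 3 is therefore estimated at 10000 nM, in a range from 4000 nM to 25000 nM.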

Compound 3, concentration for total growth inhibition: 14800 nM
Compound 3: the middle estimate sits 1.5-fold (0.17 log units) below what was measured; measured number inside the range.
By their numbers in this assay, from the lowest: compound 2; then compounds 3 and 1 (each within the scatter of the next).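

In this assay, among these compounds, putting hydrogen in place of the chloro group on the aromatic carbon between two ring nitrogen atoms gives a 4.3-fold higher number from compound 2 to compound 3 (0.63 log units; beyond the scatter) and provides the first step that isolates a single place. In this pair, the chloro group at this position goes with stronger inhibition of growth, though the step is modest. Nothing shown explains this step. From the compounds shown here alone, whether an amine or a methoxy group in this place would match the chloro group remains open, as does whether the step would carry over to the side chain arrangement of compound 1.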